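Swapping one substituted phenyl group at the low-potency end

The source may hold more compounds than are shown below. What is called first, only, known or untested is meant among the compounds shown, and "the series" means these compounds.

Of the compounds shown here, three sharing one core have been measured in a functional assay on HCT-116 cells (Homo sapiens) for antiproliferative activity, with a stated time of 72 h; a higher number here means a weaker inhibitor, a lower number a stronger inhibitor. Compound 1 (`Nc1ncnn2c([C@@H]3O[C@H](CO)[C@@H](O)[C@H]3O)cc(C#CC3CC3)c12`), with 2-cyclopropylethynyl, gives 50 nM. Compound 2 (`Nc1ncnn2c([C@@H]3O[C@H](CO)[C@@H](O)[C@H]3O)cc(C#Cc3cccs3)c12`), with 2-(thiophen-2-yl)ethynyl, gives 65500 nM. Compound 3 (`Nc1ncnn2c([C@@H]3O[C@H](CO)[C@@H](O)[C@H]3O)cc(-c3ccc(F)cc3F)c12`), with 2,4-difluorophenyl, gives 59500 nM. That places compound 3 level with compound 2, as a 1.1-fold lower number from compound 2 to compound 3 (0.04 log units; within the scatter) shows, and far from compound 1, as a 1200-fold higher number from compound 1 to compound 3 (3.08 log units; beyond the scatter) shows.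

Compound 4 (`Cc1ccccc1-c1cc([C@@H]2O[C@H](CO)[C@@H](O)[C@H]2O)n2ncnc(N)c12`) carries 2-methylphenyl in place of 2,4-difluorophenyl on an aromatic carbon, two ring bonds from the ring nitrogen: 2-methylphenyl in place of 2,4-difluorophenyl on an aromatic carbon.

Two measured steps are large, a 1300-fold higher number from compound 1 to compound 2 (3.12 log units; beyond the scatter) and a 1200-fold higher number from compound 1 to compound 3 (3.08 log units; beyond the scatter), but both start from the cyclopropyl-bearing compound 1, and the change here does not involve that group. The closer precedent is the exchange between compound 2 and compound 3, which stayed within the scatter. Among the compounds with values here, no measured pair compares two substituted phenyl groups directly, so this precedent is only indirect. In this assay, no step beyond the scatter is therefore expected, and no direction is favoured. The estimated step is a 1.5-fold lower number from compound 3 to compound 4 (0.17 log units; within the scatter). Compound 4 is expected at 40000 nM, with an estimated range of 8000 nM to 100000 nM.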

Compound 4, half-maximal inhibitory concentration: > 100000 nM
Compound 4 ended at the assay's limit; the forecaster's own chance of this, stated with the estimate: 25%; middle value at least 2.5-fold (0.39 log units) away from the limit.
By their numbers in this assay, from the lowest: compound 1; then compounds 3 and 2 (each within the scatter of the next). At a limit, above all of these: compound 4.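

Within the data shown here, compound 4 gives the first direct comparison of two substituted phenyl groups on this aromatic carbon, two ring bonds from the ring nitrogen. Its floor is short (an at least 1.6-fold higher number from compound 3 to compound 4 (0.22 log units; that floor lies within the scatter)), so 2-methylphenyl in place of 2,4-difluorophenyl gives no sign of a lower number, and the floor against the thiophene-bearing compound is just as short (an at least 1.5-fold higher number from compound 2 to compound 4 (0.18 log units; that floor lies within the scatter)), while the step from the cyclopropyl-bearing compound is large (an at least 2000-fold higher number from compound 1 to compound 4 (3.30 log units; beyond the scatter)), leaving compound 1 alone at the low-number end of the series. In this assay compound 4 reads > 100000 nM, which is a limit of the assay and not a number: the limit of > 100000 nM in this assay, at which 1 of the 4 values shown sits.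

On these data alone, the true size of the step from compound 3 to compound 4 stays unknown, and with it any ranking of the two substituted phenyl groups. Also open, as far as these compounds go, is whether the low number of compound 1 depends on cyclopropyl itself or would survive on the triple bond with a longer alkyl chain or an amine in its place, given that the thiophen-2-yl compound 2 does not share it.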